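Replacing the Side Chain of Compound 3 with 2-Carboxyethyl

The compounds below may be only part of what the source reports. "The series", "measured", "known", "first", "only" and "open" are said of these compounds alone.

Values measured in a functional assay (aorta) with Rattus norvegicus as the target (a higher number here means that more compound is needed for the effect, a lower number that less compound is needed), are these
Compound 1 `COc1ccc(-c2nc(/N=C(\N)NC3CCCCC3)sc2-c2ccc(OC)cc2)cc1` gives > 100 uM (a limit)
Compound 2 `COc1ccc(-c2nc(CNC(=O)CSC)sc2-c2ccc(OC)cc2)cc1` gives 6 uM (a number)
Compound 3 `CCOC(=O)/C(C#N)=C/c1nc(-c2ccc(OC)cc2)c(-c2ccc(OC)cc2)s1` gives > 100 uM (a limit)

Compound 3 has only a limit and so no number. That places it at the limit of > 100 uM in this assay, at which 2 of the 3 values shown sit, within this small series. Compound 4 `COc1ccc(-c2nc(CCC(=O)O)sc2-c2ccc(OC)cc2)cc1` carries 2-carboxyethyl in place of 2-cyano-2-(ethoxycarbonyl)ethenyl on an aromatic carbon on the shared core. Two measured steps at this same place bear on the change. They are an at least 16-fold lower number from compound 1 to compound 2 (1.22 log units; beyond the scatter) and an at least 16-fold higher number from compound 2 to compound 3 (1.22 log units; beyond the scatter) and both are large, so the value clearly responds to this group. Neither step involves the 2-carboxyethyl group, however, and compound 2 at 6 uM is the only side chain with a readable number. A lower number is therefore expected, of uncertain size, and a second limit remains quite possible. The expected move is an at least 2.5-fold lower number from compound 3 to compound 4 (0.39 log units; beyond the scatter) in this assay by this estimate. For compound 4 the estimated value is 40 uM with an expected range from 8 uM to 100 uM in all.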

Compound 4, concentration for half-maximal effect: > 100 uM
Compound 4: no number, only a limit; the forecaster's own chance of this, stated with the estimate: 45%; middle value at least 2.5-fold (0.39 log units) from the limit.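

In this assay, compound 4 gives only a limit, > 100 uM. Compound 2 and compound 4 both keep a saturated chain carbon bound to the aromatic carbon, and carboxymethyl in place of (((methylsulfanyl)methyl)carbonyl)amino on that carbon gives an at least 16-fold higher number from compound 2 to compound 4 (1.22 log units; beyond the scatter), so a change further out on the side chain is enough to lose the readable number. The steps from compound 1 and from compound 3 to compound 4 join two limits and cannot be read, and this limit is now the most common result in the series: the limit of > 100 uM in this assay, at which 3 of the 4 values shown sit.

In this series, compound 2 remains the only one with a readable number, 6 uM, so the compounds shown do not tell which part of its side chain matters. As far as these compounds go, whether an amine, an amide without the methylsulfanyl group or a longer chain at this position would give a readable number stays open.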